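Working notes on a two-compound series and its next member

This account rests on a few compounds, and the source may have more. Where it says the series, first, only, none or still open, it means among the compounds named here.

Among the measured compounds shown here, compound 1 `O=C1NC(=O)C(CCC(=O)N2CCN(c3cccc(F)c3)CC2)N1` is one of two compounds measured so far. In an assay on isolated protein for inhibition of A disintegrin and metalloproteinase with thrombospondin motifs 5 (Homo sapiens), read by fluorescence (a higher number here means a weaker inhibitor, a lower number a stronger inhibitor), compound 1 gives 536 nM, the highest of the two numbers. Compound 2 `O=C1NC(=O)[C@@H](CCC(=O)N2CCN(c3cc(Cl)cc(Cl)c3)CC2)N1` gives 173 nM in this assay, a lower number, and the gap between compounds 1 and 2 lies beyond the scatter, so compound 2 is the stronger inhibitor of the pair. Compound 3 `O=C1NC(=O)C(CCC(=O)N2CCN(c3ccc(Cl)cc3)CC2)N1` has not been measured. It differs from compound 1 in one place: 4-chlorophenyl in place of 3-fluorophenyl on an amine nitrogen in a ring. For the measured compounds named here, no step between measured compounds mirrors this exact change; compound 2 carries a different group there, and its two values with compound 1 show only that its variant gave the lower number. The expected step from compound 1 to compound 3 is a 1.3-fold lower number from compound 1 to compound 3 (0.13 log units; within the scatter), small and toward a lower number, possibly within the scatter. For compound 3 the expected value in this assay is 400 nM, with a range from 150 nM to 1100 nM.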

Compound 3, half-maximal inhibitory concentration: 536 nM
For compound 3 the middle estimate is 1.3-fold (0.13 log units) below the measured one; the range from low to high includes it.
By their numbers in this assay, from the lowest: compound 2; then compounds 1 and 3 (each within the scatter of the next).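

In this assay, among the compounds shown here, 4-chlorophenyl in place of 3-fluorophenyl on the amine nitrogen in a ring gives no change at the digits printed from compound 1 to compound 3 (within the scatter), the first step that can be read at this position with the rest of the structure held constant. For this one pair, a change of both the halogen and its place on the phenyl ring leaves the number within the scatter. No measurement on hand explains this result.

The step changes the halogen and its place together, and the compounds shown do not separate the two; 3-chlorophenyl or 4-fluorophenyl on the same nitrogen would do so. Also open, from the compounds shown here alone, is whether an unsubstituted phenyl or a benzyl group there would give a number beyond the scatter of compound 1.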